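This account rests on a few compounds, and the source may have more. Where it says the series, first, only, none or still open, it means among the compounds named here.

Three measured compounds are built from the same set of atoms arranged in two different ways. Compound 1 `COc1ccc(Cc2ccc(OC)c(OC)c2OC)cc1N` and compound 2 `COc1ccc(Cc2cc(OC)c(OC)c(OC)c2)cc1N` have the same atoms, joined differently; the difference between the two cores is not broken down here. Compound 3 `COc1ccc(Cc2cc(OC)c(OC)c(OC)c2)cc1[N+](=O)[O-]` keeps the core of compound 2 and carries nitro in place of amino on an aromatic carbon. All three were tested in a functional assay on A549 cells (Homo sapiens) for cytotoxicity, read by XTT assay, with a stated time of 72 h; a higher number here means a weaker inhibitor, a lower number a stronger inhibitor. Compound 1 gives 2700 nM, compound 2 gives 31 nM, and compound 3 gives 26 nM. Swapping amino for nitro therefore made a 1.2-fold lower number from compound 2 to compound 3 (0.08 log units; within the scatter). Compound 1 stands apart: its number is the highest of the three, and its gaps to compound 2 and to compound 3 both lie beyond the scatter, so compound 1 is the weakest inhibitor among the measured compounds.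

Compound 4 `COc1ccc(Cc2ccc(OC)c(OC)c2OC)cc1[N+](=O)[O-]` applies the same change to compound 1: nitro in place of amino on an aromatic carbon. The surroundings of the place are described in the same words as for the pair of compound 2 and compound 3, so this is the same change on a different core. Within the data shown here, only one example of it is known, so no pattern beyond that pair can be claimed. For compound 4 a step of a 1.2-fold lower number from compound 1 to compound 4 (0.07 log units; within the scatter) is expected in this assay, because a 1.2-fold lower number from compound 2 to compound 3 (0.08 log units; within the scatter) lay within the scatter. The estimate for compound 4 in this assay is 2300 nM, with an expected range from 900 nM to 6000 nM, kept wide since a single earlier step carries it.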

Compound 4, half-maximal inhibitory concentration: > 10000 nM
Compound 4: only a limit was reported (the forecaster's own chance of this, stated with the estimate: 5%); middle value at least 4.3-fold (0.63 log units) from the limit.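

On the core of compound 1, nitro in place of amino gave an at least 3.7-fold higher number from compound 1 to compound 4 (0.56 log units; beyond the scatter), so a change that produced no step beyond the scatter on the core of compound 2 does not carry over unchanged to this core: the same change on two cores in this assay, a 1.2-fold lower number (0.08 log units; within the scatter) from compound 2 to compound 3 and an at least 3.7-fold higher number (0.56 log units; beyond the scatter) from compound 1 to compound 4, at least 4.4-fold (0.64 log units) apart, beyond the scatter of two such steps

In this assay compound 4 gives > 10000 nM, which is a limit of the assay and not a number, so the step has a known direction but no known full size: the limit of > 10000 nM in this assay, at which 1 of the 4 values shown sits.

Among these compounds, what this does not show is why the two cores answer differently, or which feature of a core decides the outcome, and with only two pairs to compare, no general rule for the series can be drawn.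

The compounds shown carry only amino or nitro at this place, so it stays open whether a hydroxyl group, an acetamide or a fluorine atom there would be tolerated on both cores or on just one. On these data alone, it also stays open whether the gap between the two cores, so wide for the amino compounds and at least as clear for the nitro compounds, would hold with such other groups.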